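Cyclohexyl on the Anilinic Nitrogen: Expected Value for Compound 3

The compounds below may be only part of what the source reports. "The series", "measured", "known", "first", "only" and "open" are said of these compounds alone.

Of the compounds shown here, two sharing one core have been measured in an assay on isolated protein for antagonist activity at Bile acid receptor (Homo sapiens), read by HTRF, with a stated time of 30 min; a higher number here means a weaker inhibitor, a lower number a stronger inhibitor. Compound 1 `CC(C)(C)c1cc(NC(=O)c2c(Cl)cc(NCc3cccs3)cc2Cl)ccc1O` gives 8600 nM there, and compound 2 `CNc1cc(Cl)c(C(=O)Nc2ccc(O)c(C(C)(C)C)c2)c(Cl)c1` gives 13900 nM. The step from the one to the other, a 1.6-fold higher number from compound 1 to compound 2 (0.21 log units; within the scatter), comes from a hydrogen in place of thiophen-2-yl on a saturated chain carbon bound to a nitrogen on an aromatic ring. Within the data shown here, compound 2 thus holds the highest of the two numbers, with compound 1 its only neighbour and that neighbour within the scatter.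

Compound 3 `CN(c1cc(Cl)c(C(=O)Nc2ccc(O)c(C(C)(C)C)c2)c(Cl)c1)C1CCCCC1` carries the change (cyclohexyl in place of hydrogen on a nitrogen on an aromatic ring), read one bond further out as methylamino to cyclohexyl(methyl)amino. Among the measured compounds shown here, the single measured step that bears on substitution at this nitrogen, a 1.6-fold higher number from compound 1 to compound 2 (0.21 log units; within the scatter), was within the scatter, so compound 3 is expected to show no step beyond the scatter, a 1.4-fold lower number from compound 2 to compound 3 (0.14 log units; within the scatter), and its estimated value in this assay is 10000 nM, within 3500 nM to 30000 nM.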

Compound 3, half-maximal inhibitory concentration: > 100000 nM
Compound 3: a limit, no number (the forecaster's own chance of this, stated with the estimate: 15%); at least 10-fold (1.00 log units) between middle value and limit.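

Substitution at this nitrogen now clearly matters: cyclohexyl in place of hydrogen gives an at least 7.1-fold higher number from compound 2 to compound 3 (0.85 log units; beyond the scatter), whereas the earlier change at the same nitrogen, a 1.6-fold higher number from compound 1 to compound 2 (0.21 log units; within the scatter), produced no step beyond the scatter. The comparison of the two ring-bearing groups gives an at least 11-fold higher number from compound 1 to compound 3 (1.06 log units; beyond the scatter), so cyclohexyl(methyl)amino and ((thiophen-2-yl)methyl)amino do not behave alike on this aromatic carbon. The reading for compound 3 is a limit of the assay and not a number: the limit of > 100000 nM in this assay, at which 1 of the 3 values shown sits.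

The compounds shown leave open whether the rise comes with the cyclohexyl ring itself or with the loss of the hydrogen on this nitrogen. Cyclohexylamino, which keeps that hydrogen, and dimethylamino, which replaces it with a small methyl group, would separate these two readings.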